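The compounds below may be only part of what the source reports. "The series", "measured", "known", "first", "only" and "open" are said of these compounds alone.

Measured so far:

Compound 1, `COc1ccc([C@H]2CC(=O)N(c3cccc(N(C)C)c3)C2)cc1OC1CCCC1`: > 10000 nM
Compound 2, `COc1ccc([C@H]2CC(=O)N(c3cccc(N)c3C)C2)cc1OC1CCCC1`: > 10000 nM
Compound 3, `COc1ccc([C@H]2CC(=O)N(c3ccccc3C(F)(F)F)C2)cc1OC1CCCC1`: > 10000 nM

Each of these three values in a functional assay on HEK293 cells (Homo sapiens) for cytotoxicity (a higher number here means that more compound is tolerated, a lower number that less compound is tolerated), is a limit of the assay rather than a number. Compound 1 therefore stands at the limit of > 10000 nM in this assay, at which 3 of the 3 values shown sit, and nothing in the numbers shown places it apart from compound 2 or compound 3.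

Compound 4, `CCCCNc1cccc(N2C[C@@H](c3ccc(OC)c(OC4CCCC4)c3)CC2=O)c1`, keeps the shared core of compound 1 and changes one group on the aromatic ring that sits on the amide-type nitrogen: butylamino in place of dimethylamino on an aromatic carbon.

The measured steps that touch this part of the molecule are a step that the two limits leave unreadable from compound 1 to compound 2, a step that the two limits leave unreadable from compound 1 to compound 3 and a step that the two limits leave unreadable from compound 2 to compound 3. Each of them swaps the whole aromatic ring on the amide-type nitrogen, yet none of them has a readable size, since both ends of every step sit at the limit. For the measured compounds named here, they show only that three quite different rings at this position all leave the cells tolerating the compound up to the limit; they give no size in either direction.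

Compound 4 is therefore expected to behave like compound 1, with a step that the limit leaves unreadable from compound 1 to compound 4 that is not expected to exceed the scatter. The estimate for compound 4 in this assay is 15000 nM, within 5000 nM to 50000 nM, most likely again reported only as a limit.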

Compound 4, half-maximal cytotoxic concentration: > 10000 nM
Compound 4 ended at the assay's limit; the forecaster's own chance of this, stated with the estimate: 75%; the middle value lies beyond the limit too.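

In this assay, for the compounds shown here, compound 1 and compound 4 both stop at a limit, and the change from dimethylamino to butylamino gives no step that can be read. No compound shown has an exact value: the limit of > 10000 nM in this assay, at which 4 of the 4 values shown sit.

The compounds shown leave open what concentration each one takes to harm the cells, and whether any of these ring changes alters it.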